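The source may hold more compounds than are shown below. What is called first, only, known or untested is meant among the compounds shown, and "the series" means these compounds.

Measured so far in an assay on CHO cells for displacement of a labelled ligand from adenosine receptor A3 (Homo sapiens), read by scintillation counting, tested at 10 uM; a lower number here means less inhibition, a higher number more inhibition at the concentration tested (going by the name of the read-out):

Compound 1, `CC(C)(C)Cc1c(-c2ccoc2)sc(N)c1C(=O)c1ccc(Cl)cc1`, gives 1%.
Compound 2, `COc1cccc(-c2sc(N)c(C(=O)c3ccc(Cl)cc3)c2CC(C)(C)C)c1`, gives 1%.
Compound 3, `Cc1ccccc1-c1sc(N)c(C(=O)c2ccc(Cl)cc2)c1CC(C)(C)C`, gives 1%.

The three compounds share one core and differ only in the aromatic group attached on an aromatic carbon of that core. None of them displaces the labelled ligand to any noticeable degree. Compound 3 stands level with the other two: no change at the digits printed from compound 1 to compound 3 (within the scatter), and no change at the digits printed from compound 2 to compound 3 (within the scatter). The remaining step, no change at the digits printed from compound 1 to compound 2 (within the scatter), shows the same picture, so swapping one aromatic group for another has so far left this assay unmoved.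

Compound 4, `Cc1noc(C)c1-c1sc(N)c(C(=O)c2ccc(Cl)cc2)c1CC(C)(C)C`, has not been measured yet. It differs from compound 3 in one place: 3,5-dimethyl-1,2-oxazol-4-yl in place of 2-methylphenyl on an aromatic carbon. The three measured swaps at this same position all bear on this change, and each of them was flat, so the expectation is again a step of no size beyond the scatter, no change at the digits printed from compound 3 to compound 4 (within the scatter), rather than any gain or loss. On that basis compound 4 is expected to give 1% in this assay, with a range from -8% to 10%.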

Compound 4, a percentage reported as inhibition, at one concentration (the size of the read-out at that concentration, not a potency): 1%
Compound 4: middle estimate and measured number agree at the digits printed, and the stated range covers the measured number.
By their numbers in this assay, from the lowest: compounds 1, 2, 3 and 4 (each within the scatter of the next).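

In this assay, replacing 2-methylphenyl with 3,5-dimethyl-1,2-oxazol-4-yl gives no change at the digits printed from compound 3 to compound 4 (within the scatter) even though the entering group is a five-membered aromatic ring with 2 hetero atoms and 2 hydrogen-bond acceptors, while the group leaving is a carbon-only six-membered ring with 0 hydrogen-bond acceptors and the same 7 heavy atoms. The other two comparisons agree, with no change at the digits printed from compound 2 to compound 4 (within the scatter) and no change at the digits printed from compound 1 to compound 4 (within the scatter), so at this aromatic carbon next to the ring sulfur, this new ring type joins the other three aromatic groups at the same low level of inhibition. Nothing in the available data bears on why this position stays so flat.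

From the compounds shown here alone, all four compounds carry an aromatic ring at this carbon, so it remains open whether a non-aromatic group, such as an amine, a carboxylic acid or a longer alkyl chain, would shift the read-out. All four also keep the neopentyl, (4-chlorophenyl)carbonyl and amino groups, which leaves open what changing any of these on the shared core would do in this assay at the concentration tested.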